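The source may hold more compounds than are shown below. What is called first, only, known or untested is meant among the compounds shown, and "the series" means these compounds.

Of the compounds shown here, three have been tested in a functional assay (Homo sapiens) for inhibition of Nucleic Acid, tested at 100 uM; on this read-out higher numbers stand for more inhibition at the one concentration tested (going by the name of the read-out) and lower numbers for less inhibition. Compound 1 `OC[C@H]1OC(n2cnc3c(Nc4ccccc4)nccc32)[C@H](O)[C@@H]1O` gives 4%, compound 3 `[O-][n+]1ccc2c(c1)ncn2C1O[C@H](CO)[C@@H](O)[C@H]1O` gives 5%, and compound 2 `CN(C)c1[nH]ccc2ncnc1-2` gives 8%. Compound 2 stands highest of the three numbers, yet its gaps to compound 3 and to compound 1 both fall within the usual scatter of repeated measurements, so the three results cannot be told apart. Compound 4 `CSc1[nH]ccc2ncnc1-2` differs from compound 2 in one place: methylsulfanyl in place of dimethylamino on an aromatic carbon. Going by the values given here, no measured pair shows how such a change moves this read-out, and all three known numbers sit near the bottom, so the step of a number 2 percentage points lower from compound 2 to compound 4 (within the scatter) is expected to stay within the scatter, in no clear direction. Compound 4 is expected to give 6%, with a range from 0% to 16%.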

Compound 4, a percentage reported as inhibition, at one concentration (the size of the read-out at that concentration, not a potency): 4%
The estimate for compound 4 lay 2 percentage points above the measured number; the measured number falls inside the stated range.
By their numbers in this assay, from the lowest: compounds 1, 4, 3 and 2 (each within the scatter of the next).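

In this assay, putting methylsulfanyl in place of dimethylamino on the aromatic carbon next to the ring nitrogen gives a number 4 percentage points lower from compound 2 to compound 4 (within the scatter). This first pair at this position therefore shows no effect of the change that can be separated from the scatter, and both compounds give small numbers. Nothing available bears on why the two groups read alike. As far as these compounds go, whether any group at this position can lift the number clear of the scatter remains open. A carboxylic acid or methoxy there, or a longer chain on the sulfur, would test this.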